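The source may report more compounds than this note shows. Statements on the series, on what has been measured and on what is new or still open speak of the compounds shown alone.

Of the compounds shown here, three with a shared core have been tested in an assay on isolated protein for displacement of a labelled ligand from metabotropic glutamate receptor 5 (Homo sapiens), with a stated time of 60 min, tested at 1 uM; a lower number here means less inhibition, a higher number more inhibition at the concentration tested (going by the name of the read-out). Compound 1 `Cc1ccc(S(=O)(=O)c2cnc3ccc(F)cc3c2N2CCC(C)CC2)cc1F` gives 86% in this assay. Compound 2 `Cc1ccc(S(=O)(=O)c2cnc3c(F)cccc3c2N2CCC(C)CC2)cc1` gives 93% in this assay, and compound 3 `CC1CCN(c2c(S(=O)(=O)c3ccc(Cl)c(Cl)c3)cnc3cc(F)ccc23)CC1` gives 94% in this assay. The three numbers lie within the usual scatter of one another, so none of the three can be called stronger or weaker than another on these data; compound 2 simply sits among them, close to both compound 3 and compound 1.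

Compound 4 `CC1CCN(c2c(S(=O)(=O)c3ccc(F)c(Cl)c3)cnc3c(F)cccc23)CC1` has not yet been measured in this assay. It differs from compound 2 in one place: 3-chloro-4-fluorophenyl in place of 4-methylphenyl on a sulfonyl sulfur. For the measured compounds named here, no pair of measured compounds differs in just one place, so there is no measured step to lean on for the size of this change. What the data do show is that compound 3, which carries two halogen atoms on the ring at the sulfonyl sulfur, gives 94% in this assay, close to compound 2. On that basis the change from compound 2 to compound 4 is expected to make no difference beyond the scatter, and the expected step is a number 3 percentage points lower from compound 2 to compound 4 (within the scatter). Compound 4 is therefore estimated to give 90% in this assay, with a likely range from 78% to 97%.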

Compound 4, a percentage reported as inhibition, at one concentration (the size of the read-out at that concentration, not a potency): 95%
Compound 4: middle estimate off by 5 percentage points, on the low side; the range from low to high includes it.
By their numbers in this assay, from the lowest: compounds 1, 2, 3 and 4 (each within the scatter of the next).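

For the compounds shown here, exchanging 4-methylphenyl for 3-chloro-4-fluorophenyl on a sulfonyl sulfur gives, in this assay, a number 2 percentage points higher from compound 2 to compound 4 (within the scatter), and this is the first step here in which only one place changes. At this position, then, a carbon-only substituent pattern and a pattern of two halogens are not told apart by this read-out, so the exchange can be made on the core of compound 2 without a change beyond the scatter. Nothing measured here bears on why the step has this size.

Going by these compounds alone, the single pair says nothing about aryl groups further from these two, so it remains open whether the number would hold with a carboxylic acid or a dimethylamino group on the ring, or with a saturated cyclohexyl ring in place of the aromatic one on the sulfonyl sulfur. A read-out at one concentration is also not a potency, so compound 2 and compound 4 could still differ in a full concentration series.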